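The source may hold more compounds than are shown below. What is called first, only, known or untested is meant among the compounds shown, and "the series" means these compounds.

In an assay on isolated protein for inhibition of long-chain fatty acid transport protein 1 (Mus musculus) (a higher number here means a weaker inhibitor, a lower number a stronger inhibitor), compound 2 `CCn1c(CNc2ccccc2)nnc1SCc1nc2cc(Cl)ccc2o1` gives 2300 nM, the lowest of the two numbers reported here. Its nearest neighbour, compound 3 `CCC(=O)c1ccc2oc(CS(=O)(=O)c3nnc(CNc4ccccc4)n3CC)nc2c1`, gives 11900 nM, a gap that lies beyond the usual scatter of this assay. Compound 1 `CCn1c(CNc2ccccc2)nnc1SCC(=O)Nc1ccc(OC)cc1` returned only a limit of this assay, > 10000 nM, so no number can be set against it. That result rests on (the limit of > 10000 nM in this assay, at which 1 of the 3 values shown sits).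

Compound 4 `CC/C(=N/OC)c1ccc2oc(CSc3nnc(CNc4ccccc4)n3CC)nc2c1` has not yet been measured. It differs from compound 2 in one place: a group of 6 heavy atoms (4 carbon, 1 nitrogen, 1 oxygen; no ring) in place of one chlorine atom, on an aromatic carbon. Compound 3 carries a different group at that same spot together with a second change elsewhere, so its weaker result cannot be tied to the aromatic substituent alone.

Within the data shown here, with no measured step to lean on, a modest shift is expected for compound 4, most likely towards a weaker result, of about a 1.5-fold higher number from compound 2 to compound 4 (0.18 log units; within the scatter). Compound 4 is therefore estimated at 3500 nM, within a range from 1200 nM to 11000 nM.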

Compound 4, half-maximal inhibitory concentration: > 10000 nM
Compound 4: no number, only a limit; the forecaster's own chance of this, stated with the estimate: 20%; middle value at least 2.8-fold (0.45 log units) from the limit.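

In this assay, the only step shown that changes this aromatic carbon and nothing else puts a group of 6 heavy atoms in place of the chloro group, and it gives an at least 4.3-fold higher number from compound 2 to compound 4 (0.63 log units; beyond the scatter). Compound 3 could not show this because it also differs in a second place, whereas this step ties a loss of binding strength directly to the swap at this position. The true size of the loss remains unknown, and the step gives only its lower bound: the limit of > 10000 nM in this assay, at which 2 of the 4 values shown sit.

The compounds shown leave open whether a small replacement, such as a fluorine atom, a methyl group or a nitrile, would keep the result of compound 2 at 2300 nM. A plain hydrogen at this spot would also be needed to tell how much the chloro group itself contributes.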